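Removing the chloro from compound 1: an expected step

This account rests on a few compounds, and the source may have more. Where it says the series, first, only, none or still open, it means among the compounds named here.

In a functional assay on CNE-2 cells (Homo sapiens) for cytotoxicity, read by MTT assay, with a stated time of 72 h (on this read-out higher numbers stand for weaker inhibition and lower numbers for stronger inhibition), two compounds have been measured. For the measured compounds named here, compound 1 `COc1cc2ncnc(NNC(=S)NC(=O)c3ccc(Cl)cc3)c2cc1OC` gives 7530 nM, the higher of the two numbers, while compound 2 `O=C(NC(=S)NNc1ncnc2ccccc12)c1cccc(Cl)c1` gives 2920 nM; the gap between them lies beyond the usual scatter, and no single-point step connects the two structures, so only these two values can be compared.

The step examined here leads from compound 1 to compound 3 `COc1cc2ncnc(NNC(=S)NC(=O)c3ccccc3)c2cc1OC`, which has not yet been measured in this assay. The change is hydrogen in place of chloro on an aromatic carbon, sitting para to a large group; cut one bond further out, it reads 4-chlorophenyl to phenyl.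

Going by the values given here, nothing among the measured pairs shows what such a change does, so the expectation rests only on the value of compound 1 in this assay, 7530 nM. The step from compound 1 to compound 3 is expected to be small, a 1.3-fold higher number from compound 1 to compound 3 (0.10 log units; within the scatter), with a slight lean toward a higher number, not clearly beyond the scatter. Compound 3 is therefore estimated at 9500 nM, with a range from 3500 nM to 26000 nM.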

Compound 3, half-maximal inhibitory concentration: 8180 nM
Estimate against measurement, compound 3: 1.2-fold (0.06 log units) above, and the stated range covers the measured number.
By their numbers in this assay, from the lowest: compound 2; then compounds 1 and 3 (each within the scatter of the next).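

In this assay, putting hydrogen in place of chloro on this aromatic carbon, para to a large group, gives a 1.1-fold higher number from compound 1 to compound 3 (0.04 log units; within the scatter). With compound 3 at 8180 nM, the 4-chlorophenyl and the phenyl cannot be told apart on this core, so the chloro is not needed for the level of cytotoxicity that compound 1 shows here. Nothing measured alongside these values offers an explanation for this result.

The compounds shown carry only chloro or hydrogen at this place on the core of compound 1, so what a methoxy, an amine or a carboxylic acid there would do remains open. From the compounds shown here alone, compound 1 and compound 2 differ in more than one place, so compound 2 at 2920 nM cannot be traced to any one of those differences, and it also remains open whether the chloro would count for as little on a core without the methoxy groups.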